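Sulfonyl-linked heterocycles: ring oxygen for ring sulfur

The compounds below may be only part of what the source reports. "The series", "measured", "known", "first", "only" and "open" are said of these compounds alone.

Measured compounds in a functional assay, read by Griess assay, with a stated time of 150 min, tested at 75 ug/mL; a higher number here means a stronger effect of the compound at the concentration tested, a lower number a weaker effect:
- compound 1 `Cc1ccc(C2CNN=C2S(=O)(=O)CC2=NCCS2)cc1`: 48.6%
- compound 2 `O=S(=O)(CC1=NCCS1)c1c(-c2ccccc2)noc1-c1ccccc1`: "not active" (no number reported)
- compound 3 `Cc1ccc(C2CNN=C2S(=O)(=O)CC2=NCCO2)cc1`: 49.7%

Compounds 1 and 3 share a core and differ only by a group of 5 heavy atoms (3 carbon, 1 nitrogen, 1 oxygen; one five-membered non-aromatic ring with 2 hetero atoms) in place of a group of 5 heavy atoms (3 carbon, 1 nitrogen, 1 sulfur; one five-membered non-aromatic ring with 2 hetero atoms), on a saturated chain carbon bound to a sulfonyl sulfur. Across this pair this assay moves by a number 1.1 percentage points higher from compound 1 to compound 3 (within the scatter), so the two values give no ground to separate them. Compound 2 carries a different core; how the core of compound 2 differs from the core of compound 1 is not broken down here. In this assay compound 2 is reported as "not active" (no number reported), with no number attached.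

Compound 4 `O=S(=O)(CC1=NCCO1)c1c(-c2ccccc2)noc1-c1ccccc1` is not yet measured. It is related to compound 2 by a group of 5 heavy atoms (3 carbon, 1 nitrogen, 1 oxygen; one five-membered non-aromatic ring with 2 hetero atoms) in place of a group of 5 heavy atoms (3 carbon, 1 nitrogen, 1 sulfur; one five-membered non-aromatic ring with 2 hetero atoms), on a saturated chain carbon bound to a sulfonyl sulfur, the same kind of change already seen from compound 1 to compound 3, and at the same place. Within the data shown here, the one measured instance of this change stayed within the scatter, so the expectation is that the change from compound 2 to compound 4 will also be small, and that compound 4 will sit close to where compound 2 sits. The absence of a number for compound 2 limits this expectation: the most likely outcome is that compound 4 is again reported without a number, and if a number does appear it is expected to be low.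

Compound 4 is estimated at 10% in this assay, with a range from 0% to 25%, resting on compound 2 being "not active" (no number reported) and on the step from compound 1 to compound 3 being a number 1.1 percentage points higher from compound 1 to compound 3 (within the scatter).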

Compound 4, a percentage reported as activity, at one concentration (the size of the read-out at that concentration, not a potency): 57.3%
For compound 4 the middle estimate is 47.3 percentage points below the measured one; measured number outside the range, above it.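

In this assay, among these compounds, compound 2 stands as "not active" (no number reported) and compound 4 at 57.3%; with no number for compound 2, no step between them can be read. The compounds shown leave open whether ring oxygen in place of ring sulfur, on a saturated chain carbon bound to a sulfonyl sulfur, acts alike on the core of compound 1 and the core of compound 2. No measurement shown offers an explanation for the result for compound 4.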